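The compounds below may be only part of what the source reports. "The series", "measured", "known", "first", "only" and "open" are said of these compounds alone.

Measured so far:
- compound 1 `CCC[C@@H](OC(C)=O)C1=C(Br)[C@@](OC)(C(Br)Br)OC1=O`: in a functional assay on Lu1 cells (Homo sapiens) for cytotoxicity (on this read-out lower numbers stand for an effect already at smaller amounts and higher numbers for an effect only at larger amounts of compound), compound 1 gives > 20 ug/mL, which is a limit of the assay and not a number.
- compound 2 `CCC[C@@H](O)C1=C(Br)/C(=C/I)OC1=O`: compound 2 gives 1.3 ug/mL.
- compound 3 `CCC[C@@H](OC(C)=O)C1=C(Br)/C(=C/I)OC1=O`: compound 3 gives 1.5 ug/mL.

Compound 2 stands lowest of the two numbers shown; the nearest is compound 3, with a 1.2-fold higher number from compound 2 to compound 3 (0.06 log units; within the scatter), so the two cannot be ordered. The third value, that of compound 1, is only a limit (the limit of > 20 ug/mL in this assay, at which 1 of the 3 values shown sits).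

Compound 4 `CCC[C@@H](O)C1=C(Br)/C(=C/Cl)OC1=O` differs from compound 2 by chloro in place of iodo on a double-bonded chain carbon bound to a double-bonded ring carbon. Going by the values given here, no measured step touches this place: the only measured step, a 1.2-fold higher number from compound 2 to compound 3 (0.06 log units; within the scatter), concerns the acetyl in place of hydrogen on an oxygen on a saturated carbon and is within the scatter, so it gives no direction for a halogen change at the double-bonded chain carbon. With nothing pointing beyond the scatter, compound 4 is expected to sit near compound 2, with an estimated step of a 1.2-fold higher number from compound 2 to compound 4 (0.09 log units; within the scatter). Compound 4 is therefore estimated at 1.6 ug/mL, in the range 0.6 ug/mL to 4.5 ug/mL.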

Compound 4, concentration for half-maximal effect: 1 ug/mL
Estimate against measurement, compound 4: 1.6-fold (0.20 log units) above; the range from low to high includes it.
By their numbers in this assay, from the lowest: compounds 4, 2 and 3 (each within the scatter of the next). At a limit, above all of these: compound 1.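

Going by these compounds alone, this is the first measured change at the double-bonded chain carbon bound to a double-bonded ring carbon: in this assay, chloro in place of iodo gives a 1.3-fold lower number from compound 2 to compound 4 (0.11 log units; within the scatter). Iodo and chloro at this carbon therefore cannot be told apart on this read-out, which compound 2 and compound 3 could not show, as both carry iodo there. Nothing measured here gives a reason for this result.

Still open, from the compounds shown here alone, is whether a group of another kind at this carbon, such as an amine, a carboxylic acid or a longer chain, would stay close to compound 2 at 1.3 ug/mL. Also open, going by these compounds, is whether acetyl in place of hydrogen on the oxygen gives the same result with chloro as it does with iodo.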